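Aryl urea series on a shared core, zebrafish readout

The source may hold more compounds than are shown below. What is called first, only, known or untested is meant among the compounds shown, and "the series" means these compounds.

Three compounds of this set have numbers in a functional assay (strain AB) with Danio rerio as the target, read by microscopy, with a stated time of 1 h; a higher number here means that more compound is needed for the effect, a lower number that less compound is needed. Compound 1 `CCN1CCc2c(sc(NC(=O)Nc3ccc(Br)cc3)c2C(N)=O)C1` gives 3130 nM. Compound 3 `CCN1CCc2sc(NC(=O)Nc3ccc(Cl)cc3)c(C(N)=O)c2C1` gives 4610 nM, and compound 2 `CC(C)(C)CN1CCc2c(sc(NC(=O)Nc3ccc(Cl)cc3)c2C(N)=O)C1` gives 5560 nM. For the measured compounds named here, compound 1 has the smallest of the three numbers, yet its gaps to compound 3 and to compound 2 both lie within the scatter, so the three cannot be told apart on these numbers; no single-change pair among them is available for a step.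

Compound 4 `CCN1CCc2c(sc(NC(=O)Nc3cccc(C)c3)c2C(N)=O)C1` differs from compound 1 in one place: 3-methylphenyl in place of 4-bromophenyl on an amide-type nitrogen. Going by the values given here, no measured pair in the set shows what this change does, so its size is unknown here. For compound 4 the expected step of a 1.6-fold higher number from compound 1 to compound 4 (0.20 log units; within the scatter) is small, most likely none beyond the scatter, with the range left open in either direction. The estimate for compound 4 in this assay is 5000 nM, expected to fall between 2000 nM and 15000 nM.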

Compound 4, half-maximal effective concentration: 13000 nM
Beside the measured number, compound 4's estimate is 2.6-fold (0.41 log units) below it; the range from low to high includes it.
By their numbers in this assay, from the lowest: compounds 1, 3 and 2 (each within the scatter of the next); then compound 4.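

In this assay, for the compounds shown here, 3-methylphenyl in place of 4-bromophenyl on an amide-type nitrogen gives a 4.2-fold higher number from compound 1 to compound 4 (0.62 log units; beyond the scatter) and provides the first single-change step. The three earlier numbers could not be told apart, whereas this step lies beyond the scatter and shows that the group at this position can shift the number. The step arises with the heavy-atom count and the single six-membered aromatic ring of carbon unchanged, and no measured evidence on its origin is available.

The step alters both the substituent and its place on the phenyl ring, so the compounds shown do not separate these two contributions. Also open, on these data alone, is how a phenyl group carrying an amine or a carboxylic acid, or a longer alkyl chain, would read on this nitrogen.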